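A few compounds are considered here, and "the series" means these few. Any claim that something is new, unique, unknown or untested is made for them only; others in the source may bear on it.

In a functional assay on Ehrlich cells (Mus musculus) for cytotoxicity, read by trypan blue exclusion, with a stated time of 2 h, tested at 50 ug/mL (on this read-out lower numbers stand for a weaker effect and higher numbers for a stronger effect at the one concentration tested), compound 3 `C=CCNC(=S)NC1=C(C#N)C(c2ccc(Cl)cc2Cl)C2=C(CCCC2=O)N1c1ccc(S(N)(=O)=O)cc1` gives 33%, the lowest of the three numbers. Compound 2 `CCCCNC(=S)NC1=C(C#N)C(c2ccc(Cl)cc2Cl)C2=C(CCCC2=O)N1c1ccc(S(N)(=O)=O)cc1` gives 35%, with a number 2 percentage points lower from compound 2 to compound 3 (within the scatter). Compound 1 `N#CC1=C(N)N(c2ccc(S(N)(=O)=O)cc2)C2=C(C(=O)CCC2)C1c1ccc(Cl)cc1Cl` gives 65%, with a number 32 percentage points lower from compound 1 to compound 3 (beyond the scatter). Compound 4 `N#CC1=C(NC(=S)Nc2ccccc2)N(c2ccc(S(N)(=O)=O)cc2)C2=C(C(=O)CCC2)C1c1ccc(Cl)cc1Cl` differs from compound 3 by phenyl in place of allyl on an amide-type nitrogen. Of the measured steps, only the swap on that same nitrogen, a number 2 percentage points lower from compound 2 to compound 3 (within the scatter), bears directly on this change; the larger steps of a number 30 percentage points lower from compound 1 to compound 2 (beyond the scatter) and a number 32 percentage points lower from compound 1 to compound 3 (beyond the scatter) go with a group entering in place of a hydrogen on an amine nitrogen rather than with an exchange on the group. For the measured compounds named here, no measured compound carries a phenyl there, so a step within the scatter is expected, a number 2 percentage points higher from compound 3 to compound 4 (within the scatter). Compound 4 is estimated at 35%, between 20% and 52%.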

Compound 4, a percentage reported as activity, at one concentration (the size of the read-out at that concentration, not a potency): 55%
For compound 4 the middle estimate is 20 percentage points below the measured one; the measured number lies above the stated range.
By their numbers in this assay, from the lowest: compounds 3 and 2 (each within the scatter of the next); then compounds 4 and 1 (each within the scatter of the next).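

On the amide-type nitrogen, the group matters in this assay: butyl and allyl gave numbers within the scatter of each other, whereas phenyl gives a number 22 percentage points higher from compound 3 to compound 4 (beyond the scatter) and a number 20 percentage points higher from compound 2 to compound 4 (beyond the scatter). With phenyl in the group entering on the amine nitrogen, the step is a number 10 percentage points lower from compound 1 to compound 4 (within the scatter), so the clear drop seen with butyl and allyl does not extend to every group placed there. No measurement at hand accounts for this difference.

Going by these compounds, whether the aromatic ring or simply the larger group counts remains open; a cyclohexyl or a benzyl group on that nitrogen would separate the two.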